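A few compounds are considered here, and "the series" means these few. Any claim that something is new, unique, unknown or untested is made for them only; others in the source may bear on it.

Compound 1 `C=CCOC(=O)Nc1ccc([Se]C#N)cc1` and compound 2 `O=C(Nc1ccc([Se][Se]c2ccc(NC(=O)OCc3ccc([N+](=O)[O-])cc3)cc2)cc1)OCc1ccc([N+](=O)[O-])cc1` have both been tested in a functional assay on HT-29 cells (Homo sapiens) for cytotoxicity, read by MTT assay, with a stated time of 72 h; a lower number here means a stronger inhibitor of growth, a higher number a weaker inhibitor of growth. In this assay compound 1 gives 48600 nM, the higher of the two numbers, while compound 2 gives 46300 nM; the gap between them lies within the usual scatter, so the two read alike. Compound 3 `CCCCOC(=O)Nc1ccc([Se]C#N)cc1` has not yet been measured. It differs from compound 1 in one place: propyl in place of vinyl on a saturated chain carbon bound to an oxygen next to a carbonyl group. For the measured compounds named here, with no measured step to lean on, the change is expected to move the number little, if at all beyond the scatter, and the expected step is a 1.1-fold lower number from compound 1 to compound 3 (0.03 log units; within the scatter). Compound 3 is therefore estimated at 45000 nM, within a range from 20000 nM to 100000 nM.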

Compound 3, concentration for total growth inhibition: 31300 nM
The estimate for compound 3 lay 1.4-fold (0.16 log units) above the measured number, within the range that was stated.
By their numbers in this assay, from the lowest: compounds 3, 2 and 1 (each within the scatter of the next).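

At this place, on a saturated chain carbon bound to an oxygen next to a carbonyl group, replacing allyl with butyl gives a 1.6-fold lower number from compound 1 to compound 3 (0.19 log units; within the scatter) in this assay. For the compounds shown here, the first measured change here thus shows that compound 1 and compound 3 read alike, with or without the double bond outside aromatic rings. No measured evidence bears on this result.

Going by these compounds, whether a much longer chain, a benzyl group or an amine at this place would separate from these values remains open. So does whether any change here could move the number beyond the scatter.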